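This account rests on a few compounds, and the source may have more. Where it says the series, first, only, none or still open, it means among the compounds named here.

Three pyridin-3-yl thioureas on a shared piperidine core have been measured in an assay on membranes from brain for binding affinity to Lysophosphatidylserine lipase ABHD12 (Mus musculus), read by fluorescence, with a stated time of 20 min; a lower number here means a stronger inhibitor, a higher number a weaker inhibitor. Compound 1 `S=C(Nc1cccnc1)NC1CCN(c2cc(OCc3ccccc3)ccn2)CC1` gives 2800 nM. Within the data shown here, compound 2 `COc1ccc(Oc2ccnc(N3CCC(NC(=S)Nc4cccnc4)CC3)c2)cc1` gives 2900 nM; the step of a 1.0-fold higher number from compound 1 to compound 2 (0.02 log units; within the scatter) is the one directly comparable pair among the measured compounds, and it is within the scatter. Compound 3 `FC(F)(F)c1cc(Cl)nc(N2CCC(NC(=S)Nc3cccnc3)CC2)c1` gives 540 nM, the lowest of the three numbers, and its distance to both compound 1 and compound 2 is beyond the scatter, so compound 3 is the strongest inhibitor of the three in this assay.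

Compound 4 `FC(F)(F)c1ccnc(N2CCC(NC(=S)Nc3cccnc3)CC2)c1` has not yet been measured. It differs from compound 3 by hydrogen in place of chloro on an aromatic carbon; the site is on an aromatic carbon of a six-membered aromatic ring with one nitrogen, next to the ring nitrogen and meta to the trifluoromethyl group. Among the measured compounds shown here, no measured step touches this position or this kind of change: the only measured step, from compound 1 to compound 2, alters the group on the oxygen of the other pyridine and was itself within the scatter. The loss of the chloro group in compound 4 is therefore expected to give a step of a 2.0-fold higher number from compound 3 to compound 4 (0.31 log units; beyond the scatter) toward a somewhat higher number, though it may well fall within the scatter. Compound 4 is estimated at 1100 nM, within a range from 400 nM to 3000 nM.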

Compound 4, half-maximal inhibitory concentration: 640 nM
Compound 4: the middle estimate sits 1.7-fold (0.24 log units) above what was measured; the range from low to high includes it.
By their numbers in this assay, from the lowest: compounds 3 and 4 (each within the scatter of the next); then compounds 1 and 2 (each within the scatter of the next).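

In this assay, the step of a 1.2-fold higher number from compound 3 to compound 4 (0.07 log units; within the scatter) means that hydrogen and chloro on this aromatic carbon, next to the ring nitrogen, cannot be told apart, so the number of compound 3 does not depend on the chloro group. Among these compounds, compound 4 also gives the first comparisons that differ in one place across the trifluoromethyl group and the two ether groups. These are a 4.5-fold lower number from compound 2 to compound 4 (0.66 log units; beyond the scatter) for trifluoromethyl in place of 4-methoxyphenoxy and a 4.4-fold lower number from compound 1 to compound 4 (0.64 log units; beyond the scatter) for trifluoromethyl in place of benzyloxy, so the gap between these compounds persists without any chloro group present. Nothing shown here gives a reason for either result.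

As far as these compounds go, it remains open whether a larger group on the chloro-bearing carbon, such as an amine or a longer chain, would also stand level with hydrogen and chloro. From the compounds shown here alone, it is equally open whether a nitrile or a plain methyl group in place of trifluoromethyl would keep the number that compound 4 gives, 640 nM, or move it toward the ether compounds.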